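From a Difluorophenyl to a Nitrophenyl Group on Compound 4

The compounds below may be only part of what the source reports. "The series", "measured", "known", "first", "only" and "open" are said of these compounds alone.

Compound 1 `Brc1cccc(CSc2nnc(-c3ccncc3)n2-c2ccccc2)c1` and compound 2 `Brc1ccc(CSc2nnc(-c3ccncc3)n2-c2ccccc2)cc1` share a core that carries a 3-bromophenyl or a 4-bromophenyl on a saturated chain carbon bound to a sulfur. In a functional assay on MCF7 cells (Homo sapiens) for inhibition, read by MTT assay, with a stated time of 48 h (a higher number here means a weaker inhibitor, a lower number a stronger inhibitor), compound 1 gives 10000 nM, and compound 2 gives 12600 nM; the move a 1.3-fold higher number from compound 1 to compound 2 (0.10 log units; within the scatter) stays within the scatter. Compound 3 `Fc1cccc(F)c1CSc1nnc(-c2ccncc2)n1-c1ccccc1` carries a 2,6-difluorophenyl at the same place. In this assay compound 3 reaches only a limit of the assay, > 50000 nM, so its true number is not known. The steps of an at least 5.0-fold higher number from compound 1 to compound 3 (0.69 log units; beyond the scatter) and an at least 3.9-fold higher number from compound 2 to compound 3 (0.59 log units; beyond the scatter) both point to a weaker inhibitor, in line with the limit of > 50000 nM in this assay, at which 1 of the 3 values shown sits.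

Compound 4 `O=[N+]([O-])c1ccccc1CSc1nnc(-c2ccncc2)n1-c1ccccc1` differs from compound 3 by 2-nitrophenyl in place of 2,6-difluorophenyl on a saturated chain carbon bound to a sulfur. Within the data shown here, no measured step exchanges a halogen-bearing ring for a nitro-bearing one, so the only steps that bear on this change are the two leading into compound 3, which show that a change on this ring can move the number well beyond the scatter; the direction for a nitro group is open. Compound 4 is expected to land between the bromophenyl pair and the limit, with a step of an at least 2.2-fold lower number from compound 3 to compound 4 (0.35 log units; beyond the scatter) estimated toward a stronger inhibitor. The estimate for compound 4 is 22000 nM, ranging from 6000 nM to 80000 nM.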

Compound 4, half-maximal inhibitory concentration: > 50000 nM
Compound 4 was reported as a limit; the forecaster's own chance of this, stated with the estimate: 35%; middle value at least 2.2-fold (0.35 log units) from the limit.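

With 2-nitrophenyl on a saturated chain carbon bound to a sulfur, the steps are an at least 3.9-fold higher number from compound 2 to compound 4 (0.59 log units; beyond the scatter) and an at least 5.0-fold higher number from compound 1 to compound 4 (0.69 log units; beyond the scatter), so a second group besides 2,6-difluorophenyl now gives a weaker inhibitor than either bromophenyl compound. Compound 3 and compound 4 are both reported only as limits, so the step between them cannot be read, and the two groups cannot be ranked against each other. In this assay, compound 4 therefore joins compound 3 at the limit, which now holds a larger share of the compounds shown: the limit of > 50000 nM in this assay, at which 2 of the 4 values shown sit.

As far as these compounds go, how weak compound 3 and compound 4 truly are remains open. So does whether a phenyl ring carrying an amine or a carboxylic acid at this place would match the bromophenyl pair, fall to the limit, or give a stronger inhibitor.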